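A Bromine Added to the Side Phenyl Ring

The compounds below may be only part of what the source reports. "The series", "measured", "known", "first", "only" and "open" are said of these compounds alone.

Compound 1 `Cc1ccc2c(c1)C(=O)/C(=C/c1ccccc1)CN2CC(=O)O` gives 4.23% in an assay on HL-60 cells for inhibition of glutathione S-transferase P (Homo sapiens), read by spectrophotometry, tested at 20 uM; on this read-out higher numbers stand for more inhibition at the one concentration tested (going by the name of the read-out) and lower numbers for less inhibition.
Compound 2 `Cc1cccc(/C=C2\CN(CC(=O)O)c3c(Cl)cccc3C2=O)c1` gives 45.6% in this assay.
Compound 3 `COc1ccc(/C=C2\CN(CC(=O)O)c3c(C)cccc3C2=O)c(OC)c1` gives 11.7% in this assay.

Among these three numbers compound 1 has the lowest; its number and that of compound 3 lie within the scatter of each other, while compound 2 lies beyond it, higher. Compound 4 `Cc1ccc2c(c1)C(=O)/C(=C/c1ccc(Br)cc1)CN2CC(=O)O` has not been measured. It differs from compound 1 in one place: bromo in place of hydrogen on an aromatic carbon. Within the data shown here, no pair here differs by just this change; compounds 2 and 3 differ from compound 1 in several places at once, so they give no single step to lean on. The expected step is a number 7.8 percentage points higher from compound 1 to compound 4 (within the scatter), a small rise that stays within the scatter. Compound 4 is expected to give 12%, in the range 0% to 32%.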

Compound 4, a percentage reported as inhibition, at one concentration (the size of the read-out at that concentration, not a potency): 28.2%
For compound 4 the middle estimate is 16.2 percentage points below the measured one; low and high end bracket the measured number.
By their numbers in this assay, from the lowest: compounds 1 and 3 (each within the scatter of the next); then compound 4; then compound 2.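

In this assay, among these compounds, bromo in place of hydrogen gives a number 24 percentage points higher from compound 1 to compound 4 (beyond the scatter), the first step here that changes a single place. This shows that the position para to a large group on the side phenyl ring is sensitive to what sits there. No measurement shown here accounts for the rise.

From the compounds shown here alone, it remains open whether an amine or a nitrile at this position would also raise the number. Going by these compounds, it is equally open whether bromo would give a similar step with other substituents on the shared core.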